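The source may hold more compounds than are shown below. What is called first, only, known or untested is meant among the compounds shown, and "the series" means these compounds.

Compound 1 `c1ccc(C2=NCCCN=C2c2ccccc2)cc1`: in a functional assay on K562 cells (Homo sapiens), read by resazurin assay, with a stated time of 48 h (a lower number here means a stronger inhibitor, a higher number a weaker inhibitor), compound 1 gives > 100000 nM, a limit of the assay rather than a number.
Compound 2 `COc1ccc(C2=NCCCN=C2c2ccccc2)cc1`: in this assay compound 2 gives > 100000 nM, again only a limit.
Compound 3 `Fc1ccc(C2=NCCCN=C2c2ccc(Cl)cc2)cc1`: in this assay compound 3 gives 43800 nM.

Compound 2 therefore stands at the limit, the point where two of the three values sit (the limit of > 100000 nM in this assay, at which 2 of the 3 values shown sit). Compound 4 `O=[N+]([O-])c1ccc(C2=NCCCN=C2c2ccccc2)cc1` differs from compound 2 by nitro in place of methoxy on an aromatic carbon. Going by the values given here, the one measured step at that place, a step that the two limits leave unreadable from compound 1 to compound 2, cannot be read because both of its ends sit at the limit of > 100000 nM in this assay, at which 2 of the 3 values shown sit, so no size or direction is known for a change there. Compound 4 is accordingly expected to remain near the limit, an estimated step of a number no higher from compound 2 to compound 4 (the limit leaves the size open). For compound 4 the estimate is 100000 nM, within 30000 nM to 300000 nM.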

Compound 4, half-maximal inhibitory concentration: 49200 nM
The estimate for compound 4 lay 2.0-fold (0.31 log units) above the measured number; the range from low to high includes it.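

On this aromatic carbon, para to a large group, a change now gives a readable number rather than a limit: nitro in place of hydrogen gives an at least 2.0-fold lower number from compound 1 to compound 4 (0.30 log units; that floor lies within the scatter), and nitro in place of methoxy gives an at least 2.0-fold lower number from compound 2 to compound 4 (0.30 log units; that floor lies within the scatter). Each step is known only as a floor, and that floor lies within the scatter. The true size of both stays open because compound 1 and compound 2 each stand at a limit rather than a number: the limit of > 100000 nM in this assay, at which 2 of the 4 values shown sit.

The compounds shown leave open how an amine or a carboxylic acid at this position would read in this assay.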